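This account rests on a few compounds, and the source may have more. Where it says the series, first, only, none or still open, it means among the compounds named here.

Compound 1 `Cc1cnc(Nc2ccc([N+](=O)[O-])cc2)nc1Nc1nc2ccccc2s1`: 34300 nM
Compound 2 `COc1ccc(Nc2ncc(C)c(Nc3nc4ccccc4s3)n2)cc1`: > 50000 nM

In a functional assay on HeLa cells (Homo sapiens) for antiproliferative activity, read by MTT assay, with a stated time of 48 h (on this read-out lower numbers stand for stronger inhibition and higher numbers for weaker inhibition), compound 2 gives only a limit, > 50000 nM, which is the limit of > 50000 nM in this assay, at which 1 of the 2 values shown sits. Compound 1, the other measured compound, gives 34300 nM in this assay. Among the measured compounds shown here, the single measured step, an at least 1.4-fold higher number from compound 1 to compound 2 (0.16 log units; that floor lies within the scatter), can therefore be sized only as a floor. Compound 3 `Cc1cnc(Nc2cccc(F)c2)nc1Nc1nc2ccccc2s1` differs from compound 2 in one place: 3-fluorophenyl in place of 4-methoxyphenyl on a nitrogen on an aromatic ring. No measured step involves a 3-fluorophenyl, and the one step shown concerns a methoxy in place of nitro, so it offers no direct guide for this exchange. With compound 2 at a limit and compound 1 weak, a number near the edge of the measurable range is expected for compound 3, and the expected step of an at least 1.2-fold lower number from compound 2 to compound 3 (0.09 log units; that floor lies within the scatter) is small. The estimate for compound 3 in this assay is 40000 nM, between 15000 nM and 120000 nM, with a real chance that only a limit is reported again.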

Compound 3, half-maximal inhibitory concentration: 16300 nM
For compound 3 the middle estimate is 2.5-fold (0.39 log units) above the measured one, within the range that was stated.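

Changing the group on this nitrogen can move the number in this assay beyond the scatter, which the earlier nitro-to-methoxy step could not show. Among the compounds shown here, the 3-fluorophenyl group gives an at least 3.0-fold lower number from compound 2 to compound 3 (0.48 log units; beyond the scatter) and a 2.1-fold lower number from compound 1 to compound 3 (0.32 log units; beyond the scatter), so compound 3 is the only compound here with steps to both others printed as beyond the scatter. The first of these steps is only a floor because compound 2 stands at a limit: the limit of > 50000 nM in this assay, at which 1 of the 3 values shown sits.

Both steps change the substituent and its place on the phenyl ring together, so the fluorine and its ring position cannot be separated. Going by these compounds, how a 4-fluorophenyl or a 3-aminophenyl group on this nitrogen would read stays open, as does whether any group here can bring the number far below that of compound 3.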